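This account rests on a few compounds, and the source may have more. Where it says the series, first, only, none or still open, it means among the compounds named here.

Compound 1 `C=C(Br)C(=O)Nc1ccc(/C=C2\SC(=O)N(Cc3cccc(Cl)c3)C2=O)cc1`: 3400 nM
Compound 2 `Nc1ccc(/C=C2\SC(=O)N(Cc3ccccc3)C2=O)cc1`: 38000 nM
Compound 3 `C=C(Br)C(=O)Nc1ccc(/C=C2\SC(=O)N(Cc3ccccc3)C2=O)cc1`: 1100 nM

In a functional assay on L1210 cells (Mus musculus) for cytotoxicity, read by cell counting, with a stated time of 2 days (a higher number here means a weaker inhibitor, a lower number a stronger inhibitor), compound 3 stands lowest of the three numbers. Its nearest neighbour is compound 1, with a 3.1-fold lower number from compound 1 to compound 3 (0.49 log units; beyond the scatter); compound 2 lies furthest away, with a 35-fold lower number from compound 2 to compound 3 (1.54 log units; beyond the scatter). Compound 4 `C=C(Br)C(=O)Nc1ccc(/C=C2\SC(=O)N(Cc3ccc(F)cc3)C2=O)cc1` differs from compound 3 in one place: fluoro in place of hydrogen on an aromatic carbon.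

Among the compounds with values here, only one measured step bears on this change, the one from compound 1 to compound 3, where a halogen left the same benzyl ring and the number fell by a modest amount. Compound 4 puts a different and smaller halogen onto that ring, so the expectation for this assay is a step in the opposite direction, from compound 3 to compound 4, of modest size at most, and possibly nothing beyond the scatter. The large step from compound 2 to compound 3 concerns another part of the molecule and does not bear on it.

Compound 4 is therefore estimated at 1600 nM in this assay, within a range of 700 nM to 3600 nM, which means an expected step of a 1.5-fold higher number from compound 3 to compound 4 (0.16 log units; within the scatter).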

Compound 4, half-maximal inhibitory concentration: 2200 nM
For compound 4 the middle estimate is 1.4-fold (0.14 log units) below the measured one; the measured number falls inside the stated range.
By their numbers in this assay, from the lowest: compounds 3, 4 and 1 (each within the scatter of the next, the first and the last beyond it); then compound 2.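

In this assay the move to the 4-fluorobenzyl group gives a 2.0-fold higher number from compound 3 to compound 4 (0.30 log units; within the scatter) on this ring, so a fluoro para to a large group is tolerated here, whereas the chloro change had given a 3.1-fold lower number from compound 1 to compound 3 (0.49 log units; beyond the scatter) as its earlier step. The two halogen-bearing compounds cannot be told apart either, with a 1.5-fold lower number from compound 1 to compound 4 (0.19 log units; within the scatter) for the exchange of 3-chlorophenyl for 4-fluorophenyl. Nothing available explains these numbers.

Compound 1 and compound 4 differ in both the halogen and its place on the ring, so the compounds shown do not separate the two. They also leave open how a methoxy group or an amine would fare on this ring, and whether a fluoro would matter any differently without the bromoethenyl carbonyl group.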